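The source may report more compounds than this note shows. Statements on the series, on what has been measured and on what is new or still open speak of the compounds shown alone.

Within the data shown here, compound 2 `NS(=O)(=O)c1ccc(NC(=S)Nc2ccc3ncnc(Nc4cccc(Cl)c4)c3c2)cc1` holds the higher of the two numbers measured so far in a functional assay on NCI-H1975 cells (Homo sapiens) for antiproliferative activity, read by MTT assay, with a stated time of 72 h; on this read-out higher numbers stand for weaker inhibition and lower numbers for stronger inhibition. In this assay compound 2 gives 39800 nM, while compound 1 `NS(=O)(=O)c1ccc(NC(=S)Nc2ccc3ncnc(Nc4ccc(F)c(Cl)c4)c3c2)cc1` gives 15800 nM. Among the measured compounds shown here, the single measured step, a 2.5-fold higher number from compound 1 to compound 2 (0.40 log units; beyond the scatter), belongs to a change in which a fluoro group is removed from an aromatic carbon, and it shows that a small change on that ring is enough to move the number beyond the scatter.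

Compound 3 `NS(=O)(=O)c1ccc(NC(=S)Nc2ccc3ncnc(Nc4ccc(OCc5cccc(F)c5)c(Cl)c4)c3c2)cc1` differs from compound 2 by (3-fluorobenzyl)oxy in place of hydrogen on an aromatic carbon. For the measured compounds named here, none of the measured compounds carries a group of this kind at this place, so the step from compound 1 to compound 2 bears on it only in a loose way: it shows that this ring is sensitive to substitution, not which direction a large new group will take. With that in mind, compound 3 is expected to show a 5.0-fold lower number from compound 2 to compound 3 (0.70 log units; beyond the scatter), in the direction of stronger inhibition, though with a wide range. The estimate for compound 3 is 8000 nM, between 2000 nM and 40000 nM.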

Compound 3, half-maximal inhibitory concentration: 10300 nM
The estimate for compound 3 lay 1.3-fold (0.11 log units) below the measured number, and the stated range covers the measured number.
By their numbers in this assay, from the lowest: compounds 3 and 1 (each within the scatter of the next); then compound 2.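

In this assay, the place on an aromatic carbon ortho to a chloro group and para to a large group turns out to accept far more than a single fluoro: putting (3-fluorobenzyl)oxy, with its 9 heavy atoms, where compound 2 has hydrogen gives a 3.9-fold lower number from compound 2 to compound 3 (0.59 log units; beyond the scatter) and so brings stronger inhibition. Comparing this large group with fluoro at the same place gives a 1.5-fold lower number from compound 1 to compound 3 (0.19 log units; within the scatter), so the two groups cannot be told apart on this read-out, even though they differ greatly in size. Nothing at hand explains why two such different groups read alike.

Still open, from the compounds shown here alone, is whether the fluoro on the benzyl ring matters at all, which a plain benzyloxy group would test, and whether a small methoxy group or an amine at this place would read like fluoro and (3-fluorobenzyl)oxy or like hydrogen. Also open, going by these compounds, is whether a longer chain between the oxygen and the added ring would push the number lower, or whether the values at this place have already levelled off.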